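Adding a second chloro to compound 1

The source may hold more compounds than are shown below. What is called first, only, known or untested is meant among the compounds shown, and "the series" means these compounds.

compound 1 `CC(=O)N[C@@H](CSC(=O)Nc1cccc(Cl)c1)C(=O)O`: > 200000 nM (a limit)
compound 2 `CC(=O)N[C@@H](CSC(=O)Nc1ccccc1)C(=O)O`: 178000 nM
compound 3 `CC(=O)N[C@@H](CSC(=O)Nc1ccc([N+](=O)[O-])cc1Cl)C(=O)O`: > 200000 nM (a limit)
compound 4 `CC(=O)N[C@@H](CSC(=O)Nc1cc(Cl)cc(Cl)c1)C(=O)O`: not yet measured

All values come from a functional assay on GC3/C1 cells (Homo sapiens) for cytotoxicity, read by MTT assay, with a stated time of 6 days; on this read-out lower numbers stand for stronger inhibition and higher numbers for weaker inhibition. Compound 1 gives > 200000 nM there, which is a limit and not a number. That places it at the limit of > 200000 nM in this assay, at which 2 of the 3 values shown sit. Compound 4 differs from compound 1 by one change: chloro in place of hydrogen on an aromatic carbon, with chloro in place of hydrogen on an aromatic carbon, meta to a chloro group. Going by the values given here, the only measured step involving a chloro runs the other way, an at least 1.1-fold lower number from compound 1 to compound 2 (0.05 log units; that floor lies within the scatter). No step beyond the scatter is therefore expected in this assay, and a reading that gives only a limit is quite possible. The expected step is a number no higher from compound 1 to compound 4 (the limit leaves the size open). For compound 4 the estimated value is 200000 nM, with an expected range of 90000 nM to 400000 nM.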

Compound 4, half-maximal inhibitory concentration: > 200000 nM
Compound 4 ended at the assay's limit; the forecaster's own chance of this, stated with the estimate: 60%; the middle value lies on the limit itself.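

In this assay, going by these compounds alone, compound 1 and compound 4 each give only a limit, so no step between them can be read. The compounds shown leave open whether the second chloro of compound 4 changes the value at all.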